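The source may report more compounds than this note shows. Statements on the series, on what has been measured and on what is new or still open speak of the compounds shown alone.

Compound 1 `NS(=O)(=O)c1ccc(NC(=S)Nc2ccc3ncnc(Nc4ccc(F)c(Cl)c4)c3c2)cc1` carries a 3-chloro-4-fluorophenyl group on a nitrogen of the shared core. In a functional assay on A549 cells (Homo sapiens) for antiproliferative activity, read by MTT assay, with a stated time of 72 h (on this read-out higher numbers stand for weaker inhibition and lower numbers for stronger inhibition), compound 1 gives > 40000 nM, which is a limit of the assay rather than a number. Compound 2 `Cc1ccc(Nc2ncnc3ccc(NC(=S)Nc4ccc(S(N)(=O)=O)cc4)cc23)cc1` differs in one place, with 4-methylphenyl in place of 3-chloro-4-fluorophenyl on a nitrogen on an aromatic ring, and in this assay compound 2 gives 2840 nM. That step, an at least 14-fold lower number from compound 1 to compound 2 (1.14 log units; beyond the scatter), shows that the group on this nitrogen can move the number a long way, while the limit of > 40000 nM in this assay, at which 1 of the 2 values shown sits, means its true size is not known. Compound 3 `NS(=O)(=O)c1ccc(NC(=S)Nc2ccc3ncnc(Nc4ccc(OCc5cccc(F)c5)c(Cl)c4)c3c2)cc1` keeps the chloro group and instead brings ((3-fluorobenzyl)oxy in place of fluoro on an aromatic carbon). For the measured compounds named here, no measured step mirrors this change, so the expectation rests only on the direction of that one step. Compound 3 is expected to give 15000 nM in this assay, within a range of 3000 nM to 40000 nM, an estimated at least 2.6-fold lower number from compound 1 to compound 3 (0.42 log units; beyond the scatter).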

Compound 3, half-maximal inhibitory concentration: > 40000 nM
Compound 3 was reported as a limit; the forecaster's own chance of this, stated with the estimate: 40%; at least 2.6-fold (0.42 log units) between middle value and limit.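

Compound 1 and compound 3 both stand at a limit of the assay rather than at a number, so no step between them can be read: the limit of > 40000 nM in this assay, at which 2 of the 3 values shown sit.

The compounds shown leave open how far (3-fluorobenzyl)oxy in place of fluoro truly moves the number in this assay.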